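Pyrazine for Pyridine on the Ether Arm

A few compounds are considered here, and "the series" means these few. Any claim that something is new, unique, unknown or untested is made for them only; others in the source may bear on it.

Compound 1 `O=C(COCc1ccccc1)N1CCN(c2cc(Cl)ccn2)CC1`: 570 nM
Compound 2 `O=C(COCc1ccccn1)N1CCN(c2ccc(Cl)cc2Cl)CC1`: 310 nM

In a functional assay on HEK293 cells for positive allosteric modulation of metabotropic glutamate receptor 5 (Homo sapiens), read by FLIPR and calcium flux (a higher number here means that more compound is needed for the effect, a lower number that less compound is needed), compound 1 gives 570 nM and compound 2 gives 310 nM; the two lie within the scatter of each other, so neither can be called the more potent. Compound 3 `O=C(COCc1cnccn1)N1CCN(c2ccc(Cl)cc2Cl)CC1` differs from compound 2 by pyrazin-2-yl in place of pyridin-2-yl on a saturated chain carbon bound to an oxygen on a saturated carbon. Among the compounds with values here, no measured pair shows this change, so no step can be read from the data. The expected step in this assay is none beyond the scatter, leaning if anything slightly upward. For compound 3 the estimate is 420 nM, within 150 nM to 1200 nM, which means an expected step of a 1.4-fold higher number from compound 2 to compound 3 (0.13 log units; within the scatter).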

Compound 3, half-maximal effective concentration: 5200 nM
Compound 3: the middle estimate sits 12-fold (1.09 log units) below what was measured; the whole stated range lies below it.
By their numbers in this assay, from the lowest: compounds 2 and 1 (each within the scatter of the next); then compound 3.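

Pyrazin-2-yl in place of pyridin-2-yl on the saturated chain carbon brings a 17-fold higher number from compound 2 to compound 3 (1.22 log units; beyond the scatter) in this assay and so shows that this position does not accept the two aromatic rings alike. Within the data shown here, the exchange keeps the count of heavy atoms and adds only one ring nitrogen and one hydrogen-bond acceptor, yet the step is large. Nothing available accounts for this step. On these data alone, whether the number of ring nitrogens or their place matters more remains open, as does whether a pyridin-3-yl or a pyrimidin-2-yl here would stand nearer compound 2 or compound 3.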